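Chloro for methyl on the pendant aryl ring

The compounds below may be only part of what the source reports. "The series", "measured", "known", "first", "only" and "open" are said of these compounds alone.

The series shares an anilide-acetamide linker joined to a basic six-membered ring, with the distal aryl group varied. Compound 1 `CCc1cccc(NC(=O)CN2CCN(c3ccccn3)CC2)c1` gives 1310 nM in a functional assay on cells for antagonist activity at D(4) dopamine receptor (Homo sapiens), read by TR-FRET and cAMP accumulation, with a stated time of 30 min; a lower number here means a stronger inhibitor, a higher number a weaker inhibitor. Compound 2 `Cc1cccc(NC(=O)CN2CCN(c3cccc4ccccc34)CC2)c1` gives 2520 nM in this assay. Compound 3 `Cc1ccc(C2CCN(CC(=O)Nc3cccc(C)c3)CC2)cc1` gives 3060 nM in this assay, the highest of the three numbers; its gap to compound 2 is within the scatter, so no order between those two can be read, while its gap to compound 1 is beyond the scatter.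

Compound 4 `Cc1cccc(NC(=O)CN2CCC(c3ccc(Cl)cc3)CC2)c1` is not yet measured. It differs from compound 3 in one place: chloro in place of methyl on an aromatic carbon. For the measured compounds named here, no measured pair in this set makes this same exchange, so there is no step to lean on. A single-atom swap of this kind at the far end of the molecule is expected to move the number little, and the step from compound 3 to compound 4 in this assay is expected to stay within the scatter, with a slight lean toward a lower number at most.

The expected outcome for compound 4 in this assay is 2500 nM, in a range from 1000 nM to 6500 nM, the estimated step being a 1.2-fold lower number from compound 3 to compound 4 (0.09 log units; within the scatter).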

Compound 4, half-maximal inhibitory concentration: 70200 nM
For compound 4 the middle estimate is 28-fold (1.45 log units) below the measured one, and the stated range ends below it.
By their numbers in this assay, from the lowest: compounds 1, 2 and 3 (each within the scatter of the next, the first and the last beyond it); then compound 4.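

Exchanging 4-methylphenyl for 4-chlorophenyl gives a 23-fold higher number from compound 3 to compound 4 (1.36 log units; beyond the scatter) in this assay, so this aromatic carbon, para to a large group, is far from indifferent to what it carries. The change leaves the heavy-atom count, the ring count, the hydrogen-bond donor and acceptor counts and the net charge as they were, yet that single exchange is enough for a step of this size. For the compounds shown here, the earlier compounds differ from one another in more than one place and offered no step at all, so this pair gives the first reading of a single change, and no available evidence accounts for its size.

From the compounds shown here alone, it remains open whether the step belongs to chloro specifically or to any replacement of methyl here; hydrogen, fluoro, methoxy or ethyl on the same carbon would separate these cases. Going by these compounds alone, it also remains open whether the same exchange gives a step of similar size when the distal group is the one carried by compound 1 or by compound 2.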